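The compounds below may be only part of what the source reports. "The series", "measured", "known", "first", "only" and "open" are said of these compounds alone.

Measured in an ADME assay on Caco-2 cells (Homo sapiens) for permeability, in the apical to basolateral direction; a higher number here means that the compound crosses the layer faster, a lower number that the compound crosses the layer more slowly:
Compound 1, `CNC(=O)c1cc(Oc2ccc3oc(Nc4ccccc4F)nc3c2)ccn1`, gives 10 10^-6 cm/s.
Compound 2, `CNC(=O)c1cc(Oc2ccc3oc(Nc4cccc(C(C)C)c4)nc3c2)ccn1`, gives 10 10^-6 cm/s.
Compound 3, `CNC(=O)c1cc(Oc2ccc3oc(Nc4ccc(Br)cc4)nc3c2)ccn1`, gives 10 10^-6 cm/s.

The three share one core and differ only in the substituted phenyl group carried on the nitrogen attached to the aromatic ring. Compound 3 stands level with compounds 1 and 2 at the digits shown. The steps among the three all stay within the scatter: no change at the digits printed from compound 1 to compound 3 (within the scatter), no change at the digits printed from compound 2 to compound 3 (within the scatter), and likewise no change at the digits printed from compound 1 to compound 2 (within the scatter). Each of those steps exchanges one whole substituted phenyl group for another, and none of them moved the reading beyond the scatter.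

Compound 4, `CCc1ccc(Nc2nc3cc(Oc4ccnc(C(=O)NC)c4)ccc3o2)cc1`, has not yet been measured. It comes from compound 3 by a more modest change: ethyl in place of bromo on an aromatic carbon. Everything else in the molecule stays as in compound 3.

All three measured steps bear on this case. Each replaced the group on that same nitrogen with a different substituted phenyl, and the reading held steady. Swapping ethyl for bromo on one aromatic carbon is a smaller alteration than any of them, so no step beyond the scatter is anticipated; the expected step is no change at the digits printed from compound 3 to compound 4 (within the scatter). Compound 4 is therefore estimated to give 10 10^-6 cm/s, with a range from 5 10^-6 cm/s to 20 10^-6 cm/s.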

Compound 4, apparent permeability: 10 10^-6 cm/s
For compound 4 middle estimate and measured number coincide at the digits printed; the measured number falls inside the stated range.
By their numbers in this assay, from the lowest: compounds 1, 2, 3 and 4 (each within the scatter of the next).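

In this assay, among these compounds, the step at this aromatic carbon, para to a large group, shows no change at the digits printed from compound 3 to compound 4 (within the scatter); unlike the earlier steps, which exchanged one whole substituted phenyl group for another, this one keeps the 4-substituted phenyl and trades a single bromine atom for the two carbons of ethyl. The new 4-ethylphenyl group also fits the level pattern set by the other aryl groups, with no change at the digits printed from compound 2 to compound 4 (within the scatter) and no change at the digits printed from compound 1 to compound 4 (within the scatter), so all four compounds, with their fluoro, isopropyl, bromo and ethyl substituents, now read alike. No separate measurement is available to explain why the reading stays level.

From the compounds shown here alone, all four substituents are halogens or simple alkyl groups, so it remains open whether an amine or a carboxylic acid at this para position, or a longer chain in place of ethyl, would hold the reading level. Only the phenyl group varies across these compounds, which leaves the effect of any change to the shared core, such as to its methyl amide, unknown.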